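A few compounds are considered here, and "the series" means these few. Any claim that something is new, unique, unknown or untested is made for them only; others in the source may bear on it.

Measured in an ADME assay on microsomes from liver (Homo sapiens) for metabolic stability, tested at 2.5 uM; a lower number here means slower removal, a higher number faster removal of the compound:

Compound 1 `COc1cccc(-c2c(S(=O)(=O)c3ccc(OC)c(Cl)c3)cnc3cc(F)ccc23)c1`: 1.71 mL/min
Compound 2 `COc1ccc(S(=O)(=O)c2cnc3c(F)cccc3c2-c2cccc(F)c2)cc1`: 3.03 mL/min
Compound 3 `Cc1ccc(S(=O)(=O)c2cnc3cc(F)ccc3c2-c2ccc(F)cc2)cc1C`: 9.25 mL/min

Compound 3 gives the highest number of the three, beyond the scatter relative to both compound 2 and compound 1. Compound 4 `COc1ccc(S(=O)(=O)c2cnc3cc(F)ccc3c2-c2ccc(F)cc2)cc1Cl` is not yet measured. Its change from compound 3 is 3-chloro-4-methoxyphenyl in place of 3,4-dimethylphenyl on a sulfonyl sulfur.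

Compound 1 also carries a 3-chloro-4-methoxyphenyl on its sulfonyl sulfur, though its other groups differ, and its number in this assay is the lowest of the three; compound 2 carries a related methoxyphenyl there and also sits well under compound 3. On this basis a decrease beyond the scatter is expected for compound 4, a step of about a 3.1-fold lower number from compound 3 to compound 4 (0.49 log units; beyond the scatter). The value of compound 4 in this assay is estimated at 3 mL/min, within 1.5 mL/min to 6 mL/min.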

Compound 4, intrinsic clearance in a liver preparation (reported as CLH), per the amount of preparation that the assay uses: 1.29 mL/min
Compound 4: the middle estimate sits 2.3-fold (0.37 log units) above what was measured, and the stated range ends above it.
By their numbers in this assay, from the lowest: compounds 4, 1 and 2 (each within the scatter of the next, the first and the last beyond it); then compound 3.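

In this assay, within the data shown here, the swap of 3-chloro-4-methoxyphenyl in place of 3,4-dimethylphenyl on a sulfonyl sulfur gives a 7.2-fold lower number from compound 3 to compound 4 (0.86 log units; beyond the scatter) in the first comparison where only this group differs. With that group kept, 4-fluorophenyl in place of 3-methoxyphenyl on an aromatic carbon gives a 1.3-fold lower number from compound 1 to compound 4 (0.12 log units; within the scatter) and so does not separate the two compounds. Nothing measured here accounts for the step. From the compounds shown here alone, whether the chlorine or the methoxy group carries the step remains open, as the two always occur together here on this ring; a 3-chlorophenyl on the sulfonyl sulfur would separate them.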